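The source may report more compounds than this note shows. Statements on the series, on what has been measured and on what is new or still open speak of the compounds shown alone.

Values in a functional assay on A-431 cells (Homo sapiens) for inhibition, read by MTT assay, with a stated time of 72 h; a higher number here means a weaker inhibitor, a lower number a stronger inhibitor:
- compound 1 `COc1ccc(-c2nnc(SCCCN3CCN(c4nc5ccccc5s4)CC3)o2)cc1` gives 56200 nM
- compound 2 `Clc1ccc(-c2nnc(SCCCN3CCN(c4nc5ccccc5s4)CC3)o2)cc1` gives 69200 nM
- compound 3 `Fc1ccc(-c2nnc(SCCCN3CCN(c4nc5ccccc5s4)CC3)o2)cc1` gives 67000 nM

Not yet measured: compound 4 `CC(C)(C)Oc1ccc(-c2nnc(SCCCN3CCN(c4nc5ccccc5s4)CC3)o2)cc1`.

Compound 3 cannot be separated from the other two measured compounds. The data show a 1.0-fold lower number from compound 2 to compound 3 (0.01 log units; within the scatter) and also a 1.2-fold higher number from compound 1 to compound 3 (0.08 log units; within the scatter). The remaining pair gives a 1.2-fold higher number from compound 1 to compound 2 (0.09 log units; within the scatter). Among these three compounds, exchanging methoxy, chloro and fluoro on the aromatic carbon has therefore produced no step beyond the scatter.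

The next change is tert-butoxy in place of fluoro on an aromatic carbon, para to a large group: tert-butoxy in place of fluoro on an aromatic carbon. The closest measured precedent is the exchange between methoxy and fluoro, seen in compound 1 with a 1.2-fold higher number from compound 1 to compound 3 (0.08 log units; within the scatter). The exchange between chloro and fluoro, a 1.0-fold lower number from compound 2 to compound 3 (0.01 log units; within the scatter), bears on it less directly. For the measured compounds named here, no measured compound carries tert-butoxy, so these steps give only limited guidance and the range is kept wide.

No shift beyond the scatter is expected in this assay, and the estimated change is a 1.2-fold lower number from compound 3 to compound 4 (0.06 log units; within the scatter). For compound 4 the expected value is 58000 nM, with an estimated range of 25000 nM to 110000 nM.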

Compound 4, half-maximal inhibitory concentration: 67000 nM
Compound 4: middle estimate off by 1.2-fold (0.06 log units), on the low side, within the range that was stated.
By their numbers in this assay, from the lowest: compounds 1, 3, 4 and 2 (each within the scatter of the next).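

In this assay the position para to a large group, on the six-membered aromatic ring of carbon only, takes tert-butoxy with its 5 heavy atoms in place of the 1 heavy atom of fluoro, and the result is no change at the digits printed from compound 3 to compound 4 (within the scatter). The other two exchanges at this position read the same way, with a 1.0-fold lower number from compound 2 to compound 4 (0.01 log units; within the scatter) for tert-butoxy in place of chloro and a 1.2-fold higher number from compound 1 to compound 4 (0.08 log units; within the scatter) for tert-butyl in place of methyl on the oxygen, so the insensitivity seen among methoxy, chloro and fluoro now extends to a substituent with considerably more heavy atoms. No measurement at hand offers an explanation for this flat response.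

The compounds shown leave open whether an amine or a carboxylic acid on this aromatic carbon would move the number beyond the scatter, since all four substituents here are uncharged and have no hydrogen-bond donor. They also leave open whether the series responds to change anywhere else, for example a longer chain in place of the one within the shared core.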